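The source may hold more compounds than are shown below. What is called first, only, known or untested is meant among the compounds shown, and "the series" means these compounds.

Measured compounds:
- compound 1, `COc1ccc(-c2cc(=O)c3c(OC)cc(OC)cc3n2C)cc1`: 26000 nM
- compound 2, `COc1ccc(-c2c(Br)c(=O)c3c(OC)cc(OC)cc3n2S(=O)(=O)c2ccc(OC)cc2)cc1`: 1900 nM

In a functional assay on SEM cells (Homo sapiens) for antiproliferative activity, with a stated time of 72 h (a lower number here means that less compound is needed, a higher number that more compound is needed for the effect), compound 1 stands highest of the two numbers; compound 2 gives the lower number, and that gap lies beyond the scatter. Compound 3, `COc1ccc(-c2cc(=O)c3c(OC)cc(OC)cc3n2S(=O)(=O)c2ccc(C#N)cc2)cc1`, differs from compound 1 by (4-cyanophenyl)sulfonyl in place of methyl on an aromatic nitrogen. No single-change step between measured compounds is available, so the expectation rests only on the two numbers shown. The step from compound 1 to compound 3 is expected to be a clear decrease, a 6.5-fold lower number from compound 1 to compound 3 (0.81 log units; beyond the scatter). Compound 3 is therefore estimated at 4000 nM in this assay, with a range of 1200 nM to 15000 nM.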

Compound 3, half-maximal effective concentration: 1300 nM
The estimate for compound 3 lay 3.1-fold (0.49 log units) above the measured number, within the range that was stated.
By their numbers in this assay, from the lowest: compounds 3 and 2 (each within the scatter of the next); then compound 1.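

In this assay, the aromatic nitrogen proves to be a place where one change moves the number a long way: (4-cyanophenyl)sulfonyl in place of methyl gives a 20-fold lower number from compound 1 to compound 3 (1.30 log units; beyond the scatter), a large step beyond the scatter. Earlier, compound 1 and compound 2 differed in more than one place, so this gain could not be assigned to the nitrogen substituent alone. Nothing available explains the size of this step. Going by these compounds, it remains open whether the nitrile matters or the sulfonyl group alone carries the step. On these data alone, how an amine or a carboxylic acid in place of the nitrile would read is also open.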